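Replacing hydroxy with cyano in a small series

The source may hold more compounds than are shown below. What is called first, only, known or untested is meant among the compounds shown, and "the series" means these compounds.

Measured in a functional assay on MKN-45 cells (Homo sapiens) for inhibition, with a stated time of 72 h; on this read-out higher numbers stand for weaker inhibition and lower numbers for stronger inhibition:
- compound 1 `COc1ccc(S(=O)(=O)N2CCc3cccc(-c4ccco4)c32)cc1`: 42 nM
- compound 2 `COc1ccc(-c2cccc3c2N(S(=O)(=O)c2ccc(OC)cc2)CC3)cc1`: 211 nM
- compound 3 `COc1ccc(S(=O)(=O)N2CCc3cccc(-c4ccc(O)cc4)c32)cc1`: 82.6 nM

Compound 3 cannot be told apart from compound 1, since the data show a 2.0-fold higher number from compound 1 to compound 3 (0.29 log units; within the scatter). It does separate from compound 2, with a 2.6-fold lower number from compound 2 to compound 3 (0.41 log units; beyond the scatter).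

Compound 4 `COc1ccc(S(=O)(=O)N2CCc3cccc(-c4ccc(C#N)cc4)c32)cc1` has not been measured. It has cyano in place of hydroxy on an aromatic carbon. Among the compounds with values here, no measured compound carries cyano, so the evidence is indirect. The closest guide is the hydroxy-to-methoxy comparison just given, a modest step on the same group. The change from furan-2-yl to 4-methoxyphenyl, a 5.0-fold higher number from compound 1 to compound 2 (0.70 log units; beyond the scatter), is also modest. A large change is therefore not expected. Compound 2, which also lacks hydroxy, gives 211 nM, so a slight lean towards a higher number seems reasonable. The expected step is a 1.6-fold higher number from compound 3 to compound 4 (0.20 log units; within the scatter), which would be small. Compound 4 is estimated at 130 nM, with an expected range from 45 nM to 380 nM.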

Compound 4, half-maximal inhibitory concentration: 17.2 nM
Compound 4: the middle estimate sits 7.6-fold (0.88 log units) above what was measured; the measured number lies below the stated range.
By their numbers in this assay, from the lowest: compound 4; then compounds 1 and 3 (each within the scatter of the next); then compound 2.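

Putting cyano in place of hydroxy on this six-membered aromatic ring, para to a large group, gives a 4.8-fold lower number from compound 3 to compound 4 (0.68 log units; beyond the scatter) in this assay, so a hydrogen-bond donor at this spot is not required for a low number. The cyano group also clearly outdoes methoxy at the same place (a 12-fold lower number from compound 2 to compound 4 (1.09 log units; beyond the scatter)), and 4-cyanophenyl gives the first clear gain over furan-2-yl (a 2.4-fold lower number from compound 1 to compound 4 (0.39 log units; beyond the scatter)), which neither of the other two phenyl groups had achieved. The data offer no measured explanation for these gains.

It remains open whether cyano is special here, since the compounds shown include no carboxylic acid, amine, chlorine or trifluoromethyl at this place. Going by these compounds, whether cyano would give the same result elsewhere on this ring also remains unknown.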